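The source may report more compounds than this note shows. Statements on the series, on what has been measured and on what is new or still open speak of the compounds shown alone.

Measured so far in a functional assay on Ehrlich cells (Mus musculus) for cytotoxicity, read by trypan blue exclusion, with a stated time of 2 h, tested at 50 ug/mL; on this read-out higher numbers stand for a weaker effect at the one concentration tested and lower numbers for a stronger effect:
compound 1 `Cc1c(C(=O)N=[N+]=[N-])[n+]([O-])c2cc(Cl)ccc2[n+]1[O-]` — 91.2%
compound 2 `COc1ccc2c(c1)[n+]([O-])c(C(=O)N=[N+]=[N-])c(C)[n+]2[O-]` — 77.9%

Among the compounds with values here, compound 1 holds the highest of the two numbers; its only neighbour is compound 2, reached by a step of a number 13.3 percentage points lower from compound 1 to compound 2 (beyond the scatter), the change being methoxy in place of chloro on an aromatic carbon.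

Compound 3 `Cc1c(NC(=O)OC(C)C)[n+]([O-])c2cc(Cl)ccc2[n+]1[O-]` differs from compound 1 at another place: a group of 7 heavy atoms (4 carbon, 1 nitrogen, 2 oxygen; no ring) in place of a group of 5 heavy atoms (1 carbon, 3 nitrogen, 1 oxygen; no ring), on an aromatic carbon, with (isopropoxycarbonyl)amino entering on an aromatic carbon next to the ring nitrogen. Within the data shown here, no measured step touches this position, so the single step from compound 1 to compound 2 gives no guide to size or direction here. Compound 3 is therefore expected to shift by a number 9.2 percentage points lower from compound 1 to compound 3 (within the scatter) in this assay, a step not clearly beyond the scatter. The estimate for compound 3 is 82%, within 55% to 100%.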

Compound 3, a percentage reported as activity, at one concentration (the size of the read-out at that concentration, not a potency): 96.4%
Compound 3: the middle estimate sits 14.4 percentage points below what was measured; the measured number falls inside the stated range.
By their numbers in this assay, from the lowest: compound 2; then compounds 1 and 3 (each within the scatter of the next).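

In this assay, (isopropoxycarbonyl)amino in place of the group of 5 heavy atoms gives a number 5.2 percentage points higher from compound 1 to compound 3 (within the scatter), so this position now has a measured change, and it does not separate the two compounds. Unlike the earlier methoxy-for-chloro step, this exchange stays within the scatter. No independent measurement bears on this result.

Going by these compounds, whether a free amine or a carboxylic acid on this aromatic carbon would move the number beyond the scatter remains open. So does whether methoxy in place of chloro acts the same way alongside (isopropoxycarbonyl)amino.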